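Sulfanyl side-chain variation on the shared core

The source may report more compounds than this note shows. Statements on the series, on what has been measured and on what is new or still open speak of the compounds shown alone.

Measured compounds in a functional assay on PC-9 cells (Homo sapiens) for inhibition, read by MTT assay, with a stated time of 72 h; on this read-out higher numbers stand for weaker inhibition and lower numbers for stronger inhibition:
compound 1, `Cc1cc(Nc2ccn(Cc3ccccc3)n2)n2nc(SCc3ccc(Br)cc3)nc2n1`: > 50000 nM, a limit of the assay
compound 2, `Cc1cc(Nc2cc(-c3ccccc3)[nH]n2)n2nc(SCC(=O)c3ccccc3)nc2n1`: 4450 nM
compound 3, `Cc1cc(Nc2cc(-c3ccc(F)cc3)[nH]n2)n2nc(SCc3ccc(Br)cc3)nc2n1`: 6210 nM

Compound 2 gives the lower of the two numbers, but compound 3 sits within the scatter of it, so no order between them is claimed. Compound 1 reports only a limit (the limit of > 50000 nM in this assay, at which 1 of the 3 values shown sits).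

Compound 4, `Cc1cc(Nc2cc(-c3ccccc3)[nH]n2)n2nc(SCC3CC3)nc2n1`, is the next analogue: cyclopropyl in place of benzoyl on a saturated chain carbon bound to a sulfur. Among the measured compounds shown here, no step between measured compounds is available for this change, so the expectation rests on compound 2 alone. The step of a 2.0-fold higher number from compound 2 to compound 4 (0.31 log units; beyond the scatter) is expected to be a modest weakening, of a size at the edge of the scatter. Compound 4 is estimated at 9000 nM, with a range from 3000 nM to 30000 nM.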

Compound 4, half-maximal inhibitory concentration: > 50000 nM
Compound 4 gave a limit, no number (the forecaster's own chance of this, stated with the estimate: 20%); middle value at least 5.5-fold (0.74 log units) away from the limit.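

In this assay, the side chain on the sulfur gives the series its first step at a single place: an at least 11-fold higher number from compound 2 to compound 4 (1.05 log units; beyond the scatter), with cyclopropyl in place of benzoyl. Benzoyl on this saturated chain carbon therefore cannot be replaced by cyclopropyl with a measurable value retained. The full size of the step stays unknown, since compound 4 gives a limit and not a number: the limit of > 50000 nM in this assay, at which 2 of the 4 values shown sit.

The compounds shown leave open whether the carbonyl or the aromatic ring of benzoyl matters here. An amide or a longer alkyl chain in place of benzoyl on that carbon would bear on this.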